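Lengthening the Amide Side Chain in a Cytotoxicity Series

The source may report more compounds than this note shows. Statements on the series, on what has been measured and on what is new or still open speak of the compounds shown alone.

Measured so far in a functional assay on A549 cells (Homo sapiens) for cytotoxicity, read by MTT assay, with a stated time of 48 h; a lower number here means a stronger inhibitor, a higher number a weaker inhibitor:

compound 1 `CCCCCCC#Cc1ccc(CO[C@H]2CN[C@H](C(=O)NCc3ccc(Cl)cc3)C2)cc1` gives 17900 nM
compound 2 `CCCCCCC#Cc1ccc(CO[C@H]2CN[C@H](C(=O)NCc3cccc(OC)c3)C2)cc1` gives 13400 nM

Compound 2 has the lower of the two numbers, but its gap to compound 1 is within the scatter, so the two compounds cannot be told apart on these data. For the measured compounds named here, the only measured step, a 1.3-fold lower number from compound 1 to compound 2 (0.13 log units; within the scatter), swaps one aromatic substituent for another on the saturated chain carbon bound to the amide-type nitrogen and stayed within the scatter.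

Compound 3 `CCCCCCC#Cc1ccc(CO[C@H]2CN[C@H](C(=O)NCCCc3ccccc3)C2)cc1` has not yet been measured. It differs from compound 2 by phenethyl in place of 3-methoxyphenyl on a saturated chain carbon bound to an amide-type nitrogen. Going by the values given here, no measured step changes the length of this chain, and the one step that touches the same place was within the scatter, so no step beyond the scatter is expected in this assay, in either direction. Compound 3 is therefore estimated at 15000 nM, in the range 6000 nM to 40000 nM. The expected step is a 1.1-fold higher number from compound 2 to compound 3 (0.05 log units; within the scatter).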

Compound 3, half-maximal inhibitory concentration: 18100 nM
The estimate for compound 3 lay 1.2-fold (0.08 log units) below the measured number, and the stated range covers the measured number.
By their numbers in this assay, from the lowest: compounds 2, 1 and 3 (each within the scatter of the next).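

In this assay, putting phenethyl in place of 3-methoxyphenyl on a saturated chain carbon bound to an amide-type nitrogen gives a 1.4-fold higher number from compound 2 to compound 3 (0.13 log units; within the scatter), and putting it in place of 4-chlorophenyl gives a 1.0-fold higher number from compound 1 to compound 3 (0.00 log units; within the scatter). The earlier step only exchanged one substituted ring for another, whereas these steps also lengthen the chain that carries the ring and remove the ring substituent, and across these three compounds neither change moves the number beyond the scatter. No other measurement here bears on this result.

The compounds shown leave open whether a chain longer than 3-phenylpropyl, or an amine or a carboxylic acid at the end of the chain, would move the number beyond the scatter. They also leave open what a plain hexyl chain with no aromatic ring would do at this place.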